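Compound 4: Swapping Ethoxycarbonyl for Carboxy

The source may hold more compounds than are shown below. What is called first, only, known or untested is meant among the compounds shown, and "the series" means these compounds.

Measured so far in a functional assay on the whole organism (strain Hartley) for inhibition, with Cavia porcellus as the target, with stated times of 15 min and 2 min; on this read-out lower numbers stand for an effect already at smaller amounts and higher numbers for an effect only at larger amounts of compound:
- compound 1 `CCCCC1([C@@H](O)/C=C/C2CCC(=O)[C@@H]2CCCCCCC(=O)O)CCC1` gives 0.0203 mg/kg
- compound 2 `CCCCC1([C@H](O)/C=C/C2CCC(=O)[C@@H]2CCCCSCC(=O)OCC)CCC1` gives 0.3 mg/kg
- compound 3 `CCCCC1([C@H](O)/C=C/C2CCC(=O)[C@@H]2C/C=C\CCCC(=O)OCC)CCC1` gives 0.135 mg/kg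

Compound 2 has the highest number of the three, so it needs the largest dose for its effect. Compound 3 sits closest to it on the lower side, and that gap lies beyond the usual scatter. Compound 1 lies furthest away, also clearly beyond the scatter.

The next compound to be tested is compound 4 `CCCCC1([C@H](O)/C=C/C2CCC(=O)[C@@H]2CCCCSCC(=O)O)CCC1`. It differs from compound 2 in one place only: hydrogen in place of ethyl on an oxygen next to a carbonyl group. In words, hydrogen replaces ethyl on an oxygen next to a carbonyl group, which turns ethoxycarbonyl into carboxy.

Within the data shown here, no measured pair shows this change alone, so any forecast is uncertain. Among the measured compounds shown here, the only hint is compound 1, which already carries a carboxy group and gives 0.0203 mg/kg. It differs from compound 2 in other places too, so it is weak evidence. A moderate move toward a lower number is therefore expected in this assay, though no real change remains possible. The estimated size of this move is a 3.0-fold lower number from compound 2 to compound 4 (0.48 log units; beyond the scatter). For compound 4 the expected value is 0.1 mg/kg, with an estimated range from 0.025 mg/kg to 0.35 mg/kg.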

Compound 4, dose for half-maximal effect: 0.171 mg/kg
The estimate for compound 4 lay 1.7-fold (0.23 log units) below the measured number; the range from low to high includes it.
By their numbers in this assay, from the lowest: compound 1; then compounds 3, 4 and 2 (each within the scatter of the next, the first and the last beyond it).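

In this assay, hydrogen in place of ethyl on an oxygen next to a carbonyl group, which turns ethoxycarbonyl into carboxy, gives a 1.8-fold lower number from compound 2 to compound 4 (0.24 log units; within the scatter). Among these compounds, this pair is the first to show the change on its own, and with the rest of the structure held fixed, the ethoxycarbonyl and carboxy forms cannot be told apart on this read-out. Nothing available here explains this result.

Going by these compounds, it remains open whether the same swap would also leave the number within the scatter on the other chains, meaning the carboxy counterpart of compound 3 and the ethoxycarbonyl counterpart of compound 1, each of which would form a single-change pair of its own. Also open, on these data alone, is how other groups in this place would read, such as a methoxycarbonyl group, a butoxycarbonyl group with its longer chain, or a primary amide, since ethoxycarbonyl and carboxy are the only two forms compared here on an otherwise identical structure.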